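A Chloro Group Enters the Hydroxyphenyl Ring of Compound 2

The source may hold more compounds than are shown below. What is called first, only, known or untested is meant among the compounds shown, and "the series" means these compounds.

Measured so far:
compound 1 `Cc1c(C(=O)N/N=C\c2cccc(O)c2O)oc2cccc(O)c12` — 5030 nM
compound 2 `Cc1c(C(=O)N/N=C\c2ccccc2O)oc2cccc(O)c12` — 10600 nM

Both compounds were tested in a functional assay on MGC-803 cells (Homo sapiens) for inhibition, read by MTT assay; on this read-out higher numbers stand for weaker inhibition and lower numbers for stronger inhibition. Compound 1 gives 5030 nM, while compound 2 gives 10600 nM. Among the measured compounds shown here, the only step between them, a 2.1-fold higher number from compound 1 to compound 2 (0.32 log units; beyond the scatter), comes from hydrogen in place of hydroxy on an aromatic carbon. On these two numbers compound 2 stands highest, with compound 1 as its nearest neighbour.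

Compound 3 `Cc1c(C(=O)N/N=C\c2cc(Cl)ccc2O)oc2cccc(O)c12` is the next structure, not yet measured. It differs from compound 2 as follows: chloro in place of hydrogen on an aromatic carbon. For the measured compounds named here, no measured step in this set involves a chloro group; the step of a 2.1-fold higher number from compound 1 to compound 2 (0.32 log units; beyond the scatter) concerns the loss of a hydroxy group on the other side of the same ring and so bears on the change only in that it shows this ring is sensitive to substitution. The expectation is therefore a small change, with a modest fall in the number somewhat more likely than a rise. The estimate for compound 3 in this assay is 7000 nM, within a range of 3000 nM to 20000 nM. This estimate means an expected step of a 1.5-fold lower number from compound 2 to compound 3 (0.18 log units; within the scatter).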

Compound 3, half-maximal inhibitory concentration: 4160 nM
Estimate against measurement, compound 3: 1.7-fold (0.23 log units) above, and the stated range covers the measured number.
By their numbers in this assay, from the lowest: compounds 3 and 1 (each within the scatter of the next); then compound 2.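

In this assay, among the compounds shown here, chloro on the aromatic carbon para to a hydroxy group gives a 2.5-fold lower number from compound 2 to compound 3 (0.41 log units; beyond the scatter), which shows that this position of the ring, carrying only hydrogen in the earlier compounds, also responds to substitution and that a group other than hydroxy can lower the number. The comparison of the two substituted rings gives a 1.2-fold lower number from compound 1 to compound 3 (0.08 log units; within the scatter), so 5-chloro-2-hydroxyphenyl and 2,3-dihydroxyphenyl cannot be told apart in this assay, even though the chloro and the second hydroxy group sit in different places and differ in kind. Nothing available here accounts for the step that chloro produces or for this match between the two rings.

The compounds shown leave open whether the gain belongs to chloro in particular or would also appear with bromo, methyl, methoxy or an amine at the same position. They also leave open whether chloro and the second hydroxy group would lower the number further if both stood on one ring, and whether chloro still lowers it when the hydroxy group para to it is absent.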